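The source may hold more compounds than are shown below. What is called first, only, known or untested is meant among the compounds shown, and "the series" means these compounds.

Working notes on the series. The shared core carries a triple- or double-bonded aryl arm on a saturated ring carbon. Compound 1 `Cc1ccc(-n2nccn2)c(C(=O)N2C[C@H](C#Cc3cccnc3)CC[C@H]2C)c1` gives 28 nM in a functional assay on isolated protein for antagonist activity at Orexin receptor type 2 (Homo sapiens), read by FLIPR and calcium flux; on this read-out lower numbers stand for stronger inhibition and higher numbers for weaker inhibition. Compound 2 `Cc1ccc(-n2nccn2)c(C(=O)N2C[C@H](/C=C/c3ccc(F)cn3)CC[C@H]2C)c1` gives 34 nM in this assay; the step of a 1.2-fold higher number from compound 1 to compound 2 (0.08 log units; within the scatter) shows that exchanging both the linker and the aryl group leaves the number essentially unchanged. Compound 3 `Cc1ccc(-n2nccn2)c(C(=O)N2C[C@H](C#Cc3ccc(CO)cn3)CC[C@H]2C)c1` is recorded as "not determined" (no result reported) in this assay, so it stands nowhere on the numbers shown; it can only be placed by its neighbours, compound 1 and compound 2.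

Compound 4 `Cc1ccc(-n2nccn2)c(C(=O)N2C[C@H](C#Cc3cnccc3O)CC[C@H]2C)c1` differs from compound 3 by 4-hydroxypyridin-3-yl in place of 5-(hydroxymethyl)pyridin-2-yl on a triple-bonded carbon. Among the measured compounds shown here, no measured step changes a hydroxyl-bearing pyridine on this arm, so the only step that bears on the question is the one from compound 1 to compound 2, which was within the scatter and argues for tolerance of aryl variation at this position. A number near compound 1 is therefore expected for compound 4, with a wide range to cover the untested hydroxyl: compound 4 is estimated at 60 nM, between 15 nM and 250 nM.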

Compound 4, half-maximal inhibitory concentration: 52 nM
For compound 4 the middle estimate is 1.2-fold (0.06 log units) above the measured one, and the stated range covers the measured number.
By their numbers in this assay, from the lowest: compounds 1, 2 and 4 (each within the scatter of the next).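

In this assay hydroxy on an aromatic carbon of the ethynyl arm gives a 1.9-fold higher number from compound 1 to compound 4 (0.27 log units; within the scatter) and is thus tolerated at this position in the one direct comparison shown. The listed change of both linker and aryl group, a 1.5-fold higher number from compound 2 to compound 4 (0.18 log units; within the scatter), also stays within the scatter, so compound 4 extends the tolerance seen on this arm to a hydroxyl-bearing pyridine. No measurement at hand accounts for this tolerance.

Steps to compound 3 cannot be read, which leaves the 5-(hydroxymethyl)pyridin-2-yl arm unplaced against the 4-hydroxypyridin-3-yl arm. Also open, on these data alone, is whether an amine or a carboxylic acid on the pyridine, or a longer chain on the triple-bonded carbon, would be accepted as well.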